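Sulfur substituent: phenethyl to 4-fluorophenyl

This account rests on a few compounds, and the source may have more. Where it says the series, first, only, none or still open, it means among the compounds named here.

compound 1 `Nc1ccccc1NC(=O)c1ccc(CSc2cccc(F)c2)cc1` 3280 nM
compound 2 `Cc1ccc(SCc2ccc(C(=O)Nc3ccccc3N)cc2)cc1` 3740 nM
compound 3 `Nc1ccccc1NC(=O)c1ccc(CSCCc2ccccc2)cc1` 4880 nM

In a functional assay on SMMC-7721 cells (Homo sapiens) for antiproliferative activity, read by CCK-8 assay, with a stated time of 72 h (a higher number here means a weaker inhibitor, a lower number a stronger inhibitor), compound 3 at 4880 nM stands within the scatter of both other compounds, as a 1.5-fold higher number from compound 1 to compound 3 (0.17 log units; within the scatter) and a 1.3-fold higher number from compound 2 to compound 3 (0.12 log units; within the scatter) show. Compound 4 `Nc1ccccc1NC(=O)c1ccc(CSc2ccc(F)cc2)cc1` carries 4-fluorophenyl in place of phenethyl on a sulfur and keeps the rest of the structure. Those same two steps bear on this change, the nearer being a 1.5-fold higher number from compound 1 to compound 3 (0.17 log units; within the scatter) with its 3-fluorophenyl group. The exchange of the two ring groups, a 1.1-fold higher number from compound 1 to compound 2 (0.06 log units; within the scatter) as measured, also stays within the scatter. Among the measured compounds shown here, no 4-fluorophenyl compound has a measured value yet. In this assay no step beyond the scatter is expected. The expected step is a 1.4-fold lower number from compound 3 to compound 4 (0.14 log units; within the scatter) and would lie within the scatter. Compound 4 is estimated at 3500 nM (expected range 1800 nM to 6500 nM).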

Compound 4, half-maximal inhibitory concentration: 5770 nM
The estimate for compound 4 lay 1.6-fold (0.22 log units) below the measured number; the measured number falls inside the stated range.
By their numbers in this assay, from the lowest: compounds 1, 2, 3 and 4 (each within the scatter of the next).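

In this assay the 4-fluorophenyl group on the sulfur stays within the scatter of phenethyl (a 1.2-fold higher number from compound 3 to compound 4 (0.07 log units; within the scatter)), of 4-methylphenyl (a 1.5-fold higher number from compound 2 to compound 4 (0.19 log units; within the scatter)) and of 3-fluorophenyl (a 1.8-fold higher number from compound 1 to compound 4 (0.25 log units; within the scatter)). The two fluorophenyl groups are therefore not told apart here, and fluoro in place of methyl on an aromatic carbon leaves the number within the scatter as well. No supporting measurement bears on this result. Going by these compounds, whether any group on this sulfur can move the number beyond the scatter stays open; an amine, a carboxylic acid or a longer chain there would test it.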